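The compounds below may be only part of what the source reports. "The series", "measured", "known", "first", "only" and "open" are said of these compounds alone.

Measured so far:
- compound 1, `Cc1ccc2oc(=O)c(C(=O)Nc3ccccc3)cc2c1`: 15.3 nM
- compound 2, `Cc1ccc2occ(C(=O)Nc3ccccc3)c(=O)c2c1`: 21.4 nM
- compound 3, `COc1ccc2occ(C(=O)Nc3ccccc3)c(=O)c2c1`: 41.8 nM

In an assay on cells for inhibition of Amine oxidase [flavin-containing] B (Homo sapiens), read by fluorescence and Amplex Red, using microsomes, with a stated time of 15 min (on this read-out lower numbers stand for stronger inhibition and higher numbers for weaker inhibition), compound 3 gives the highest of the three numbers. Its closest neighbour is compound 2: the step of a 2.0-fold higher number from compound 2 to compound 3 (0.29 log units; within the scatter) is within the scatter, so on this read-out compounds 2 and 3 cannot be told apart. Compound 1 sits at a lower number than compound 3, and that gap lies beyond the scatter, so compound 1 is the one that clearly inhibits more strongly than compound 3.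

Compound 4, `COc1ccc2occ(C(=O)Nc3cccc(O)c3)c(=O)c2c1`, has not been measured. It differs from compound 3 by hydroxy in place of hydrogen on an aromatic carbon. Within the data shown here, the only measured step, a 2.0-fold higher number from compound 2 to compound 3 (0.29 log units; within the scatter), alters a group on the shared core, not on the phenyl of the amide, so no measured step bears on this change. Among the measured compounds shown here, with no precedent in these data, the expected step of a 1.0-fold lower number from compound 3 to compound 4 (0.02 log units; within the scatter) is one of no more than the scatter, in no certain direction. Compound 4 is therefore estimated at 40 nM, with a range from 15 nM to 110 nM.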

Compound 4, half-maximal inhibitory concentration: 114 nM
For compound 4 the middle estimate is 2.9-fold (0.45 log units) below the measured one, outside the stated range (above it).
By their numbers in this assay, from the lowest: compounds 1, 2 and 3 (each within the scatter of the next, the first and the last beyond it); then compound 4.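

Among these compounds, the earlier compounds varied only the shared core, leaving the phenyl of the amide untouched, so this is the first look at a change on that ring. In this assay, among the compounds shown here, phenyl to 3-hydroxyphenyl gives a 2.7-fold higher number from compound 3 to compound 4 (0.44 log units; beyond the scatter) and so weakens inhibition modestly, whereas the one earlier step on the core stayed within the scatter. Nothing in these data explains why adding a single hydroxy on this aromatic carbon costs inhibition.

The compounds shown leave open whether the loss belongs to the hydroxy itself or to any group at this place, which a methoxy group or an amine there could help separate. They also leave open whether the same change would have a similar effect on the core of compound 1, which differs from the core of compound 3.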